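Swapping a lactam ring for a triazolylmethyl arm

A few compounds are considered here, and "the series" means these few. Any claim that something is new, unique, unknown or untested is made for them only; others in the source may bear on it.

Measured so far:
- compound 1, `CC(C)C(c1ccc(-c2ccc3cccc(F)c3c2)[nH]c1=O)N1CCCCC1=O`, gives 6.4 nM in an assay on CHO cells for displacement of a labelled ligand from prostaglandin E2 receptor EP3 subtype (Homo sapiens), read by radioligand binding; a lower number here means a stronger inhibitor, a higher number a weaker inhibitor
- compound 2, `CC(C)C(c1ccc(-c2ccc3cccc(F)c3c2)[nH]c1=O)N1CCN/C1=N\C#N`, gives 23 nM in this assay
- compound 3, `CCn1ncc2c(F)cc(-c3ccc(C(CC)(CC)c4nnc[nH]4)c(=O)[nH]3)cc21`, gives 17 nM in this assay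

Compound 1 has the lowest number of the three, so it is the strongest binder shown; compound 3 comes nearest and compound 2 lies furthest away. Compound 4, `CC(C)C(Cc1nnc[nH]1)c1ccc(-c2ccc3cccc(F)c3c2)[nH]c1=O`, keeps the core of compound 1 and changes only the group on the saturated chain carbon: (4H-1,2,4-triazol-3-yl)methyl in place of 2-oxopiperidin-1-yl on a saturated chain carbon bound to an aromatic carbon and a saturated chain carbon. Going by the values given here, the one measured step at this place, a 3.6-fold higher number from compound 1 to compound 2 (0.56 log units; beyond the scatter), shows that replacing the 2-oxopiperidin-1-yl group with a different nitrogen-containing ring cost a modest amount of binding. Compound 3, which carries a triazole ring in a related position on a differently decorated core, still gives a number close to compound 1, so the triazole itself does not appear to be a poor choice. A modest loss beyond the scatter is therefore expected for compound 4, about a 2.3-fold higher number from compound 1 to compound 4 (0.37 log units; beyond the scatter). Compound 4 is estimated at 15 nM, most likely between 5 nM and 45 nM.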

Compound 4, inhibition constant: 10 nM
Compound 4: the middle estimate sits 1.5-fold (0.18 log units) above what was measured, and the stated range covers the measured number.
By their numbers in this assay, from the lowest: compounds 1, 4, 3 and 2 (each within the scatter of the next, the first and the last beyond it).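

In this assay, the (4H-1,2,4-triazol-3-yl)methyl group does as well as the 2-oxopiperidin-1-yl group on this saturated chain carbon, with a 1.6-fold higher number from compound 1 to compound 4 (0.19 log units; within the scatter) and so no real difference between them. This place therefore accepts either an aromatic five-membered ring on a one-carbon link or a non-aromatic six-membered ring, while the five-membered non-aromatic ring with 2 hetero atoms falls behind, with a 2.3-fold lower number from compound 2 to compound 4 (0.36 log units; beyond the scatter) in favour of the triazole arm. No measurement available here explains this ranking.

Still open is whether the methyl link matters, since the compounds shown include neither a triazole ring attached directly to this carbon nor one on a longer chain. They also leave open how a carboxylic acid or an amine would fare at this place.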